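Nitro for methoxy on a chalcone-type cytotoxicity series

This account rests on a few compounds, and the source may have more. Where it says the series, first, only, none or still open, it means among the compounds named here.

Two compounds of this set have been examined in an ADME assay on Vero cells (Chlorocebus sabaeus) for cytotoxicity, read by MTT assay, with a stated time of 72 h; on this read-out lower numbers stand for higher toxicity in this test and higher numbers for lower toxicity in this test. Compound 1 `COC(=O)c1cc(-c2cccc(NC(=O)c3ccc(/C=C/C(=O)c4cc(F)ccc4F)cc3)c2)on1` carries a 2,5-difluorophenyl on the carbonyl carbon, and in this assay compound 1 gives > 40 ug/mL, which is a limit of the assay rather than a number. Compound 2 `COC(=O)c1cc(-c2cccc(NC(=O)c3ccc(/C=C/C(=O)c4ccc(OC)c(OC)c4)cc3)c2)on1` carries a 3,4-dimethoxyphenyl at the same place, and in this assay compound 2 gives > 50 ug/mL, again a limit and not a number. The step that the two limits leave unreadable from compound 1 to compound 2 therefore cannot be read because the limit of > 40 ug/mL in this assay, at which 1 of the 2 values shown sits, and the limit of > 50 ug/mL in this assay, at which 1 of the 2 values shown sits, are where the two values sit, and compound 2 stands only at a limit within the numbers shown.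

Compound 3 `COC(=O)c1cc(-c2cccc(NC(=O)c3ccc(/C=C/C(=O)c4ccc(OC)c([N+](=O)[O-])c4)cc3)c2)on1` differs from compound 2 by nitro in place of methoxy on an aromatic carbon. Among the compounds with values here, no measured step bears on this change, since the only step available is unreadable, so the expectation for compound 3 rests on compound 2 alone. Compound 3 is expected to remain at the same limit in this assay, and the expected step of a number no higher from compound 2 to compound 3 (the limit leaves the size open) is none beyond the scatter. The estimate for compound 3 in this assay is 50 ug/mL, with a range from 20 ug/mL to 100 ug/mL.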

Compound 3, half-maximal cytotoxic concentration: > 40 ug/mL
Compound 3: only a limit was reported; the forecaster's own chance of this, stated with the estimate: 75%; the middle value is on the limit's open side.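

In this assay compound 3 gives > 40 ug/mL, which is a limit of the assay and not a number. No step can be read from compound 3 to compound 1 or compound 2; all three compounds stand at limits. The compounds shown leave open whether nitro in place of methoxy on an aromatic carbon changes the half-maximal cytotoxic concentration at all.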